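This account rests on a few compounds, and the source may have more. Where it says the series, first, only, none or still open, it means among the compounds named here.

Measured in a functional assay on A549 cells (Homo sapiens) for inhibition; on this read-out higher numbers stand for weaker inhibition and lower numbers for stronger inhibition:
- compound 1 `CCCCCOC(=O)Nc1nc(=O)n(C2O[C@H](C(=O)O)[C@@H](O)[C@H]2O)cc1F`: 0.17 ug/mL
- compound 2 `C=CCOC(=O)Nc1nc(=O)n(C2O[C@H](C(=O)O)[C@@H](O)[C@H]2O)cc1F`: 0.04 ug/mL
- compound 3 `C#CCOC(=O)Nc1nc(=O)n(C2O[C@H](C(=O)O)[C@@H](O)[C@H]2O)cc1F`: 0.005 ug/mL

Of these three, compound 3 has the lowest number, 0.005 ug/mL, which makes it the strongest inhibitor so far. The next compound, compound 4 `O=C(Nc1nc(=O)n(C2O[C@H](C(=O)O)[C@@H](O)[C@H]2O)cc1F)OCc1ccccc1`, has not yet been measured. Its difference from compound 3 is phenyl in place of ethynyl on a saturated chain carbon bound to an oxygen next to a carbonyl group, or propargyl to benzyl.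

Within the data shown here, all the measured steps involve this same place. The closest comparison is an 8.0-fold lower number from compound 2 to compound 3 (0.90 log units; beyond the scatter), and the largest is a 34-fold lower number from compound 1 to compound 3 (1.53 log units; beyond the scatter). The remaining step is a 4.3-fold lower number from compound 1 to compound 2 (0.63 log units; beyond the scatter). Neither vinyl nor butyl matches ethynyl, but phenyl has not been tried, so these steps give only a rough guide. Losing ethynyl is expected to raise the number by a modest step. The expected step is a 10-fold higher number from compound 3 to compound 4 (1.00 log units; beyond the scatter). For compound 4 the estimated value is 0.05 ug/mL, with an expected range from 0.012 ug/mL to 0.25 ug/mL.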

Compound 4, half-maximal inhibitory concentration: 0.37 ug/mL
For compound 4 the middle estimate is 7.4-fold (0.87 log units) below the measured one; measured number above the stated range.
By their numbers in this assay, from the lowest: compound 3; then compound 2; then compound 1; then compound 4.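

Phenyl brings the first ring to this place, and in this assay swapping it in for ethynyl gives the largest step in the series, a 74-fold higher number from compound 3 to compound 4 (1.87 log units; beyond the scatter), so the strength seen with the triple bond does not carry over to an aromatic ring. Phenyl also falls behind both other groups, with a 9.3-fold higher number from compound 2 to compound 4 (0.97 log units; beyond the scatter) and a 2.2-fold higher number from compound 1 to compound 4 (0.34 log units; beyond the scatter), which makes compound 4 the weakest of the four inhibitors. Nothing shown here explains why phenyl fares so poorly at this place.

As far as these compounds go, it remains open whether the loss comes from having a ring at all or from this particular ring, which a cyclohexyl or pyridyl group could help to separate. A longer chain carrying the triple bond, such as butynyl, would show whether the gain with ethynyl survives added length.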